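A few compounds are considered here, and "the series" means these few. Any claim that something is new, unique, unknown or untested is made for them only; others in the source may bear on it.

Measured so far in an assay on HEK-293T cells for inhibition of diacylglycerol lipase-alpha (Homo sapiens), read by colorimetric assay; on this read-out higher numbers stand for weaker inhibition and lower numbers for stronger inhibition:

- compound 1 `COc1ccc(CC2CCCCN2C(=O)n2ncc(C(O)(c3ccc(F)cc3)c3ccc(F)cc3)n2)cc1`: 5.01 nM
- compound 2 `O=C(N1CCCCC1COc1ccc(F)cc1)n1ncc(C(O)(c2ccc(F)cc2)c2ccc(F)cc2)n1`: 5.01 nM
- compound 3 `O=C(N1CCCCC1Cc1ccccc1)n1ncc(C(O)(c2ccccn2)c2ccccn2)n1`: 158 nM

Compound 2 stands level with compound 1 at the digits shown, and the two share the lowest number of the three. Among the compounds with values here, compound 3, with 158 nM in this assay, sits far higher, a gap well beyond the scatter; no single-point step connects it to compound 2, so only the two values themselves can be compared.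

The new compound is compound 4 `O=C(N1CCCCC1COc1ccccc1)n1ncc(C(O)(c2ccc(F)cc2)c2ccc(F)cc2)n1`. It differs from compound 2 by hydrogen in place of fluoro on an aromatic carbon. Within the data shown here, the one measured step that touches this part of the molecule is no change at the digits printed from compound 1 to compound 2 (within the scatter), where the 4-fluorophenoxy group entered in place of 4-methoxyphenyl without any change in the number. Among the measured compounds shown here, that step is the only guide, and it argues for a small effect of the outer ring's substituent. Compound 4 is therefore expected to stay close to compound 2, with a step of a 1.2-fold higher number from compound 2 to compound 4 (0.08 log units; within the scatter) in this assay that is not expected to exceed the scatter. The estimate for compound 4 in this assay is 6 nM, with a range from 2.5 nM to 15 nM.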

Compound 4, half-maximal inhibitory concentration: 5.01 nM
Compound 4: the middle estimate sits 1.2-fold (0.08 log units) above what was measured; measured number inside the range.
By their numbers in this assay, from the lowest: compounds 1, 2 and 4 (each within the scatter of the next); then compound 3.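

Within the data shown here, replacing 4-fluorophenoxy with phenoxy tests the fluoro on its own for the first time, and in this assay the result is no change at the digits printed from compound 2 to compound 4 (within the scatter). The phenoxy group also matches the 4-methoxyphenyl group directly, with no change at the digits printed from compound 1 to compound 4 (within the scatter), so the fluoro is not required to keep this level in the series shown. No measurement here offers an explanation for the flat result.

The compounds shown leave open whether this aromatic carbon would accept a substituent other than fluoro or hydrogen, such as an amine, a carboxylic acid or a longer chain. They also leave open whether hydrogen and fluoro would remain interchangeable at this carbon on the core of compound 3.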